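The compounds below may be only part of what the source reports. "The series", "measured", "known", "first", "only" and "open" are said of these compounds alone.

Compound 1 `ClCc1ccccc1Cn1cnc2ncnc(Cl)c21`: 51300 nM
Compound 2 `ClCc1ccc(Cn2cnc3c(Cl)nc(Cl)nc32)cc1`: "not determined" (no result reported)
Compound 3 `Nc1nc(Cl)c2ncn(Cc3cccc(CCl)c3)c2n1`: > 100000 nM, a limit of the assay

The three compounds were tested in a functional assay on HOP-92 cells (Homo sapiens) for cytotoxicity, read by sulforhodamine B assay, with a stated time of 48 h; a higher number here means that more compound is tolerated, a lower number that less compound is tolerated. Among the compounds with values here, compound 1 is the only one with a single number, giving 51300 nM in this assay. For compound 2 no result was reported in this assay. For compound 3 this assay reports only a limit, > 100000 nM. On the whole set this is summed up by the limit of > 100000 nM in this assay, at which 1 of the 3 values shown sits. Within the data shown here, compound 1 therefore stands alone as the one measured number, with one further entry as a limit and one without a result.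

Compound 4 `ClCc1ccccc1Cn1cnc2nc(Cl)nc(Cl)c21` has not yet been measured in this assay. It differs from compound 1 by chloro in place of hydrogen on an aromatic carbon. Among the measured compounds shown here, no pair of measured compounds shows this kind of change, so the size of the step cannot be read from a measured pair. The step of a 1.2-fold higher number from compound 1 to compound 4 (0.07 log units; within the scatter) is expected to stay within the usual scatter, with no clear direction. Compound 4 is accordingly estimated at 60000 nM in this assay, with a likely range from 20000 nM to 150000 nM.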

Compound 4, concentration lethal to 50% of the cells: > 100000 nM
Compound 4: a limit, no number; the forecaster's own chance of this, stated with the estimate: 30%; at least 1.6-fold (0.22 log units) between middle value and limit.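

Within the data shown here, the pair of compound 1 and compound 4 gives the first reading of chloro in place of hydrogen on an aromatic carbon at this position, between two ring nitrogen atoms, and the step is an at least 1.9-fold higher number from compound 1 to compound 4 (0.28 log units; that floor lies within the scatter). In this assay, the added chloro group therefore does not bring the compound to a lower number, but only a floor for the step can be read, and that floor does not separate the two compounds. What can be read of the change ends at a limit of the assay rather than at a number: the limit of > 100000 nM in this assay, at which 2 of the 4 values shown sit.

The compounds shown leave open how large the step really is, since compound 4 has no single number that could be set against compound 1. They also leave open whether a methyl group or a methoxy group in place of the hydrogen at this position would give a measured number in this assay, and so whether any change here can be followed in size rather than only against a limit.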